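Removing the substituted phenyl from compound 2

The compounds below may be only part of what the source reports. "The series", "measured", "known", "first", "only" and "open" are said of these compounds alone.

In a functional assay on SNB-19 cells (Homo sapiens) for inhibition, read by sulforhodamine B assay, with a stated time of 48 h (on this read-out lower numbers stand for stronger inhibition of growth and higher numbers for weaker inhibition of growth), compound 2 `COc1cc(-c2nn(-c3cccc(NC(=O)c4ccc(Cl)c(C(F)(F)F)c4)c3)cc2-c2ccncc2)ccc1Cl` gives > 32500 nM, which is a limit and not a number. Compound 1 `COc1cc(-c2nn(-c3cccc(NC(=O)c4cccc(C(F)(F)F)c4)c3)cc2-c2ccncc2)ccc1Cl` gives > 50000 nM, which is also a limit. Going by the values given here, no measured compound in this small set therefore has an exact position in this assay.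

Compound 3 `COc1cc(-c2nn(-c3cccc(NC(=O)c4ccccc4)c3)cc2-c2ccncc2)ccc1Cl` carries phenyl in place of 4-chloro-3-(trifluoromethyl)phenyl on a carbonyl carbon. Among the compounds with values here, the only measured step that bears on this change is a step that the two limits leave unreadable from compound 1 to compound 2, with chloro in place of hydrogen on an aromatic carbon. With limits at both ends, it offers no size to carry over, so no step beyond the scatter is expected in this assay, in either direction. The expected change is a step that the limit leaves unreadable from compound 2 to compound 3. Compound 3 is estimated at 50000 nM, with an expected range from 25000 nM to 100000 nM.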

Compound 3, concentration for total growth inhibition: > 100000 nM
Compound 3 ended at the assay's limit (the forecaster's own chance of this, stated with the estimate: 80%); middle value at least 2.0-fold (0.30 log units) from the limit.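

In this assay, going by these compounds alone, compound 1, compound 2 and compound 3 all stand only as limits, so no step among them can be read. The compounds shown leave open whether swapping 4-chloro-3-(trifluoromethyl)phenyl for phenyl on the carbonyl carbon changes growth inhibition at all.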